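Changing the carbonyl substituent of compound 2

The source may report more compounds than this note shows. Statements on the series, on what has been measured and on what is new or still open speak of the compounds shown alone.

Values in an ADME assay on MT4 cells (Homo sapiens) for cytotoxicity, read by MTT assay; a lower number here means that less compound is tolerated, a higher number that more compound is tolerated:
- compound 1 `O=C1c2ccccc2C(=O)N1CCOC(=S)N(C(=O)c1cccc([N+](=O)[O-])c1)c1ccc(Cl)cc1`: 18000 nM
- compound 2 `Cc1ccc(C(=O)N(C(=S)OCCN2C(=O)c3ccccc3C2=O)c2ccc(Cl)cc2)cc1`: > 100000 nM
- compound 3 `Cc1ccc(C(=O)N(C(=S)OCCN2C(=O)c3ccccc3C2=O)c2ccc(C)cc2)cc1`: 83000 nM

Compound 2 gives > 100000 nM, which is a limit of the assay and not a number. Compound 4 `O=C1c2ccccc2C(=O)N1CCOC(=S)N(C(=O)c1cccc(F)c1F)c1ccc(Cl)cc1` differs from it by 2,3-difluorophenyl in place of 4-methylphenyl on a carbonyl carbon. The measured step at this same place is an at least 5.5-fold higher number from compound 1 to compound 2 (0.74 log units; beyond the scatter), which lies beyond the scatter. Compound 3 bears less on the question, since an at least 1.2-fold lower number from compound 2 to compound 3 (0.08 log units; that floor lies within the scatter) concerns another place and its floor lies within the scatter. Compound 4 loses the 4-methylphenyl carried by compound 2, so a lower number is expected in this assay. The expected size of the change is an at least 2.2-fold lower number from compound 2 to compound 4 (0.34 log units; beyond the scatter). Compound 4 is estimated at 45000 nM, with an expected range of 15000 nM to 100000 nM.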

Compound 4, half-maximal cytotoxic concentration: 58000 nM
Compound 4: middle estimate off by 1.3-fold (0.11 log units), on the low side; measured number inside the range.
By their numbers in this assay, from the lowest: compound 1; then compounds 4 and 3 (each within the scatter of the next). At a limit, above all of these: compound 2.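

In this assay, 2,3-difluorophenyl in place of 3-nitrophenyl gives a 3.2-fold higher number from compound 1 to compound 4 (0.51 log units; beyond the scatter), so a second group at this carbonyl carbon now stands clear of 3-nitrophenyl. Replacing 4-methylphenyl gives an at least 1.7-fold lower number from compound 2 to compound 4 (0.23 log units; that floor lies within the scatter), and that floor alone does not separate the two groups beyond the scatter. Compound 2 remains a limit of the assay and not a number: the limit of > 100000 nM in this assay, at which 1 of the 4 values shown sits.

Still open, from the compounds shown here alone, is how a pyridine ring or a longer alkyl chain at this carbonyl carbon would read in this assay. Also open, going by these compounds, is whether the 2,3-difluorophenyl result holds with methyl in place of chloro.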